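Spiro-piperidine sulfonamides: heteroaryl swap toward compound 3

The compounds below may be only part of what the source reports. "The series", "measured", "known", "first", "only" and "open" are said of these compounds alone.

compound 1, `CCOCCN(C[C@@H](O)CN1CCCC2(CCN(c3ncnc4[nH]cc(C)c34)CC2)C1)S(=O)(=O)c1c(C)cccc1C`: 1200 nM
compound 2, `CCOCCN(C[C@@H](O)CN1CCCC2(CCN(c3ncnc4ccccc34)C2)C1)S(=O)(=O)c1c(C)cccc1C`: 2400 nM

In an assay on LNCaP cells for inhibition of RAC-alpha serine/threonine-protein kinase (Homo sapiens) (on this read-out higher numbers stand for weaker inhibition and lower numbers for stronger inhibition), compound 1 gives 1200 nM and compound 2 gives 2400 nM. Compound 2 sits at the upper of the two numbers, but its gap to compound 1 lies within the scatter, so the two are not separated by this read-out. For the measured compounds named here, the two compounds differ in more than one place, and no single step between them can be read from the pair.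

Compound 3, `CCOCCN(C[C@@H](O)CN1CCCC2(CCN(c3ncncc3C3CC3)C2)C1)S(=O)(=O)c1c(C)cccc1C`, is not yet measured. It differs from compound 2 in one place: 5-cyclopropylpyrimidin-4-yl in place of quinazolin-4-yl on an amine nitrogen in a ring. Going by the values given here, with no measured step of this kind to lean on, the step of a 1.3-fold higher number from compound 2 to compound 3 (0.10 log units; within the scatter) expected in this assay is none beyond the scatter, with at most a mild lean toward a weaker number. Compound 3 is accordingly estimated at 3000 nM, with a range from 800 nM to 12000 nM.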

Compound 3, half-maximal inhibitory concentration: 740 nM
Estimate against measurement, compound 3: 4.1-fold (0.61 log units) above; measured number outside the range, below it.
By their numbers in this assay, from the lowest: compounds 3, 1 and 2 (each within the scatter of the next, the first and the last beyond it).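

In this assay, the group on the amine nitrogen in a ring proves to be a place where the read-out moves: 5-cyclopropylpyrimidin-4-yl in place of quinazolin-4-yl gives a 3.2-fold lower number from compound 2 to compound 3 (0.51 log units; beyond the scatter). For the compounds shown here, this is the first single-place step, and it shows that the six-membered aromatic ring of carbon only in quinazolin-4-yl is not needed for a number at this level, at least when a three-membered ring of carbon enters in its stead. No measurement shown accounts for the size or direction of this step.

Going by these compounds alone, the single step changes both rings at once, so the share of each in the shift stays unresolved. Also open, from the compounds shown here alone, is how an isopropyl group, a methoxy group or a plain hydrogen in place of the cyclopropyl on the pyrimidine ring would read.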